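From oxan-4-yl to pyridin-2-yl: cytotoxicity notes

A few compounds are considered here, and "the series" means these few. Any claim that something is new, unique, unknown or untested is made for them only; others in the source may bear on it.

Of the compounds shown here, three have been read in an ADME assay on MT4 cells (Homo sapiens) for cytotoxicity, with a stated time of 5 days; on this read-out lower numbers stand for higher toxicity in this test and higher numbers for lower toxicity in this test: compound 1 (`CC(C)(C)C#Cc1cc(N(C(=O)[C@H]2CC[C@H](C)CC2)[C@H]2CC[C@H](OC3CCOCC3)CC2)c(C(=O)O)s1`), compound 2 (`CC1=CC[C@H](C(=O)N(c2cc(C#CC(C)(C)C)sc2C(=O)O)[C@H]2CC[C@](O)(CO[C@H]3CCOC3)CC2)CC1`) and compound 3 (`CON=C1CCC(N(c2cc(C#CC(C)(C)C)sc2C(=O)O)C(=O)[C@H]2CC[C@H](C)CC2)CC1`). Compound 1 gives > 20000 nM, which is a limit and not a number. Compound 2 gives > 20000 nM, also a limit. Compound 3 gives > 20000 nM, again a limit. Compound 1 therefore stands with the other two, and the set reads as the limit of > 20000 nM in this assay, at which 3 of the 3 values shown sit. Among the compounds with values here, no measured pair differs in one place, so no measured step is available for scale.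

Compound 4 (`CC(C)(C)C#Cc1cc(N(C(=O)[C@H]2CC[C@H](C)CC2)[C@H]2CC[C@H](Oc3ccccn3)CC2)c(C(=O)O)s1`) carries pyridin-2-yl in place of oxan-4-yl on an oxygen on a saturated carbon. The expectation starts from compound 1 and its limit of > 20000 nM. The expected a number no higher from compound 1 to compound 4 (the limit leaves the size open) stays within the scatter, with no direction favoured. Compound 4 is estimated at 20000 nM, with an expected range of 8000 nM to 40000 nM.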

Compound 4, half-maximal cytotoxic concentration: > 20000 nM
Compound 4 gave a limit, no number; the forecaster's own chance of this, stated with the estimate: 75%; the middle value lies on the limit itself.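

Compound 1 and compound 4 both read only as limits in this assay, so no step between them can be read: the limit of > 20000 nM in this assay, at which 4 of the 4 values shown sit.

The compounds shown leave open what actual number any of them would give in this assay, and whether pyridin-2-yl in place of oxan-4-yl shifts it.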